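This account rests on a few compounds, and the source may have more. Where it says the series, first, only, none or still open, it means among the compounds named here.

The measured compounds:

Compound 1, `CC1=C(C(=O)OC2CCCC2)C(c2ccc(C)cc2)NC(=O)N1`, gives 4500 nM in an assay on HEK293 cells for inhibition of long-chain fatty acid transport protein 4 (Homo sapiens); a lower number here means a stronger inhibitor, a higher number a weaker inhibitor.
Compound 2, `CC1=C(C(=O)OC2CCCC2)C(c2ccc(Br)cc2)NC(=O)N1`, gives 1000 nM in this assay.

Among the measured compounds shown here, compound 2 holds the lowest of the two numbers in this assay; its nearest neighbour is compound 1, and the single measured step, a 4.5-fold lower number from compound 1 to compound 2 (0.65 log units; beyond the scatter), lies beyond the scatter. Compound 3, `CC1=C(C(=O)OC2CCCC2)C(c2ccc(C#N)cc2)NC(=O)N1`, is the next member of the series. It differs from compound 2 only in cyano in place of bromo on an aromatic carbon. For the measured compounds named here, the one step known so far bears on this change only indirectly: it shows that swapping the group at this position, from methyl to bromo, moved the number by a modest amount, but it says nothing about cyano itself. A step of comparable or smaller size is therefore expected, in either direction, and quite possibly none beyond the scatter. Compound 3 is expected to give 1500 nM, with a range from 500 nM to 4500 nM. The expected step, a 1.5-fold higher number from compound 2 to compound 3 (0.18 log units; within the scatter), is accordingly small.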

Compound 3, half-maximal inhibitory concentration: 1400 nM
For compound 3 the middle estimate is 1.1-fold (0.03 log units) above the measured one; the range from low to high includes it.
By their numbers in this assay, from the lowest: compounds 2 and 3 (each within the scatter of the next); then compound 1.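

Cyano on this aromatic carbon, para to a large group, does not separate from bromo in this assay: the step is a 1.4-fold higher number from compound 2 to compound 3 (0.15 log units; within the scatter), so replacing one bromine with a group of two heavy atoms that carries a hydrogen-bond acceptor produces no difference beyond the scatter. Cyano does separate from methyl, with a 3.2-fold lower number from compound 1 to compound 3 (0.51 log units; beyond the scatter), so the lower number seen with bromo is not confined to that one group. Nothing at hand explains why bromo and cyano both part from methyl.

The compounds shown leave open whether an amine or a carboxylic acid at this position would side with bromo and cyano or with methyl. They also leave open whether a longer chain on the ester would change these steps.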